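The source may hold more compounds than are shown below. What is called first, only, known or untested is meant among the compounds shown, and "the series" means these compounds.

Three compounds have been measured in a functional assay on L1210 cells (Mus musculus) for cytotoxicity, read by MTT assay, with a stated time of 24 h; a lower number here means a stronger inhibitor, a higher number a weaker inhibitor:

- compound 1 `COc1cc(C(=O)/C=C/c2ccc(C)cc2)cc(OC)c1OC`: 50500 nM
- compound 2 `COc1cc(C(=O)/C=C/c2c(Cl)cccc2Cl)cc(OC)c1OC`: 50500 nM
- compound 3 `COc1cc(C(=O)/C=C/c2ccc(F)cc2)cc(OC)c1OC`: 46500 nM

Compound 3, at 46500 nM, stands level with the other two, since its number cannot be told apart from theirs within the scatter. The next compound, compound 4 `COc1cc(C(=O)/C=C/c2ccc(C)o2)cc(OC)c1OC`, differs from compound 3 in one group: 5-methylfuran-2-yl in place of 4-fluorophenyl on a double-bonded chain carbon bound to a double-bonded chain carbon. The 5-methylfuran-2-yl takes the place of the 4-fluorophenyl on a double-bonded chain carbon bound to a double-bonded chain carbon.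

Going by the values given here, three measured steps bear on this change. Two of them exchange the whole group at this same place: no change at the digits printed from compound 1 to compound 2 (within the scatter) and a 1.1-fold lower number from compound 2 to compound 3 (0.04 log units; within the scatter). The third is smaller, a fluoro in place of a methyl on an aromatic carbon: a 1.1-fold lower number from compound 1 to compound 3 (0.04 log units; within the scatter). All three lie within the scatter, so these three compounds give no sign that this assay responds to the group at this place. None of them, however, carries a five-membered aromatic ring, so the data do not test this kind of group directly, and the range is kept wide. No step beyond the scatter is expected in this assay. The expected step is a 1.1-fold lower number from compound 3 to compound 4 (0.04 log units; within the scatter). For compound 4 the estimate is 42000 nM, with an expected range of 20000 nM to 85000 nM.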

Compound 4, half-maximal inhibitory concentration: 46500 nM
Compound 4: the middle estimate sits 1.1-fold (0.04 log units) below what was measured; measured number inside the range.
By their numbers in this assay, from the lowest: compounds 3, 4, 1 and 2 (each within the scatter of the next).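

The 5-methylfuran-2-yl is the only group among these compounds with a five-membered aromatic ring and a hydrogen-bond acceptor, and in this assay its exchange for the 4-fluorophenyl gives no change at the digits printed from compound 3 to compound 4 (within the scatter). Set against the other two groups at this place, it gives a 1.1-fold lower number from compound 2 to compound 4 (0.04 log units; within the scatter) and a 1.1-fold lower number from compound 1 to compound 4 (0.04 log units; within the scatter), so the insensitivity seen among the three six-membered aromatic rings of carbon only now extends to this quite different ring: on a double-bonded chain carbon bound to a double-bonded chain carbon, all four groups stand level in this assay. No supporting evidence is available to account for this lack of response.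

The four groups shown are all uncharged aromatic rings without hydrogen-bond donors, so it stays open whether an amine, a carboxylic acid or a longer chain at this place would move the number beyond the scatter. On these data alone, it is also open whether this flat response reflects the group at this place at all or holds only for the shared core of compound 1, whose other parts do not vary here.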